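The compounds below may be only part of what the source reports. "The series", "measured", "known", "first", "only" and "open" are said of these compounds alone.

Working notes on the urea series built on the shared core of compound 1 `O=C(NC1CCN(Cc2ccn(-c3ccc(C(F)(F)F)cc3)c2)CC1)N1CC[C@H](O)C1`. In an assay on HEK293 cells for displacement of a labelled ligand from melanin-concentrating hormone receptor 1 (Homo sapiens) (a lower number here means a stronger inhibitor, a higher number a weaker inhibitor), compound 1 gives 125 nM. Compound 2 `O=C(NC1CCN(Cc2ccn(-c3ccc(C(F)(F)F)cc3)c2)CC1)N1CCCC1Cc1cccnc1` gives 26 nM in this assay, and compound 3 `O=C(NC1CCN(Cc2ccn(-c3ccc(C(F)(F)F)cc3)c2)CC1)N1CCCC(CO)C1` gives 23 nM. Among the compounds with values here, compound 3 has the lowest number of the three measured so far: the step of a 5.4-fold lower number from compound 1 to compound 3 (0.74 log units; beyond the scatter) is beyond the scatter, whereas the step of a 1.1-fold lower number from compound 2 to compound 3 (0.05 log units; within the scatter) is within it, so compounds 2 and 3 cannot be told apart on these numbers. Within the data shown here, the step of a 4.8-fold lower number from compound 1 to compound 2 (0.68 log units; beyond the scatter) is of the same kind and size as the one leading to compound 3.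

Compound 4 `O=C(NCC1(O)CCCCC1)NC1CCN(Cc2ccn(-c3ccc(C(F)(F)F)cc3)c2)CC1` is the next member. It differs from compound 3 in that (((1-hydroxycyclohexyl)methyl)amino in place of 3-(hydroxymethyl)piperidin-1-yl on a carbonyl carbon). Among the measured compounds shown here, no measured step covers this kind of change: the two steps from compound 1 each exchange one ring amine for another ring amine on the carbonyl carbon, and the comparison of compounds 2 and 3 shows that two different larger groups at that position give numbers within the scatter of each other. On that basis compound 4 is expected to stay near compound 3, with the step of a 1.7-fold higher number from compound 3 to compound 4 (0.24 log units; within the scatter) expected to be small and its direction open. The estimate for compound 4 in this assay is 40 nM, with a range from 12 nM to 130 nM.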

Compound 4, half-maximal inhibitory concentration: 44 nM
The estimate for compound 4 lay 1.1-fold (0.04 log units) below the measured number; the range from low to high includes it.
By their numbers in this assay, from the lowest: compounds 3, 2 and 4 (each within the scatter of the next); then compound 1.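

Within the data shown here, the ((1-hydroxycyclohexyl)methyl)amino group is the first on this carbonyl carbon with an open amino nitrogen instead of a ring amine, and its ring is of carbon only; it also counts 2 hydrogen-bond donors against 1 for 3-(hydroxymethyl)piperidin-1-yl. Even so, in this assay the result is a 1.9-fold higher number from compound 3 to compound 4 (0.28 log units; within the scatter) and a 1.7-fold higher number from compound 2 to compound 4 (0.23 log units; within the scatter), both within the scatter, so this position accepts an open amino link as well as the two ring amines on these numbers, while a 2.8-fold lower number from compound 1 to compound 4 (0.45 log units; beyond the scatter) places this group with them, clear of the 3-hydroxypyrrolidin-1-yl of compound 1. Nothing on hand accounts for these numbers.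

The compounds shown leave open whether the hydroxyl on the cyclohexyl ring contributes at all, which a plain cyclohexylmethylamino group, or a methoxy or an amine in place of that hydroxyl, would test. Also open, going by these compounds, is what the hydrogen on the amino nitrogen contributes, which a methyl on that nitrogen would test, and whether a longer chain between the cyclohexyl ring and that nitrogen keeps the number in the same range.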